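Dimethylanilino selenazole analogue: expectation before measurement

A few compounds are considered here, and "the series" means these few. Any claim that something is new, unique, unknown or untested is made for them only; others in the source may bear on it.

Measured compounds:
- compound 1, `Cc1cccc(Nc2nc3cccnc3[se]2)c1`: 56700 nM
- compound 2, `Cc1ccc(Nc2nc3cccnc3[se]2)cc1`: 235000 nM
- compound 3, `Clc1ccccc1Nc1nc2cccnc2[se]1`: 181000 nM

In a functional assay on HepG2 cells (Homo sapiens) for cytotoxicity, read by MTT assay, with a stated time of 72 h (a higher number here means a weaker inhibitor, a lower number a stronger inhibitor), compound 2 gives 235000 nM, the highest of the three numbers. Compound 3 with 181000 nM lies within the scatter of compound 2, so no order between these two can be read. Compound 1 with 56700 nM lies beyond the scatter below compound 2; with only these three compounds no wider pattern is claimed.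

Compound 4, `Cc1ccc(Nc2nc3cccnc3[se]2)cc1C`, has not been measured. It differs from compound 2 by methyl in place of hydrogen on an aromatic carbon. For the measured compounds named here, no step between measured compounds of this kind is known, so the size of the step is uncertain. Given that compound 1 gives 56700 nM, a modest move toward a lower number is expected from compound 2 to compound 4, a step estimated at a 2.0-fold lower number from compound 2 to compound 4 (0.29 log units; within the scatter). Compound 4 is therefore expected to give 120000 nM in this assay, with an estimated range from 40000 nM to 350000 nM.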

Compound 4, half-maximal inhibitory concentration: 145000 nM
For compound 4 the middle estimate is 1.2-fold (0.08 log units) below the measured one, and the stated range covers the measured number.
By their numbers in this assay, from the lowest: compound 1; then compounds 4, 3 and 2 (each within the scatter of the next).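

In this assay, methyl in place of hydrogen on an aromatic carbon, ortho to a methyl group and meta to a large group, gives a 1.6-fold lower number from compound 2 to compound 4 (0.21 log units; within the scatter) and so produces no readable shift at this position. The same kind of change, read from the other parent, gives a 2.6-fold higher number from compound 1 to compound 4 (0.41 log units; beyond the scatter) and is a modest step that can be read. This change therefore does not have one readable outcome across the two parents, although only these two steps support that statement.

Going by these compounds, whether an amine, a methoxy group or a carboxylic acid on the same aromatic carbon would give a step beyond the scatter remains open. Nothing shown here bears on why the two methyl steps read differently.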